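The compounds below may be only part of what the source reports. "The series", "measured", "known", "first", "only" and "open" are said of these compounds alone.

Compound 1 `CCCOC(=O)OCC(CO)CCn1cnc2cnc(N)nc21` gives 68000 ug/mL in a physicochemical assay for solubility, read by spectrophotometry, at 20 degrees C; on this read-out lower numbers stand for lower solubility and higher numbers for higher solubility. Compound 3 `CCCCOC(=O)OCC(CO)CCn1cnc2cnc(N)nc21` gives 15000 ug/mL. Compound 2 `CCCCCOC(=O)OCC(CO)CCn1cnc2cnc(N)nc21` gives 4200 ug/mL.

Compound 2 stands lowest of the three measured numbers: its nearest neighbour is compound 3, reached by a 3.6-fold higher number from compound 2 to compound 3 (0.55 log units; beyond the scatter), and the furthest is compound 1, separated from it by a 16-fold lower number from compound 1 to compound 2 (1.21 log units; beyond the scatter).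

Compound 4 `CCOC(=O)OCC(CO)CCn1cnc2cnc(N)nc21` differs from compound 2 by hydrogen in place of propyl on a saturated chain carbon, two bonds along the chain from an oxygen next to a carbonyl group. The measured steps that bear on this change run in the opposite sense: a 16-fold lower number from compound 1 to compound 2 (1.21 log units; beyond the scatter) came with an ethyl entering the chain, and a 4.5-fold lower number from compound 1 to compound 3 (0.66 log units; beyond the scatter) with a methyl entering it, and each lengthening of the chain lowered the number well beyond the scatter. Cutting the chain back from compound 2 to the ethyl of compound 4 is therefore expected to raise the number strongly, by a 36-fold higher number from compound 2 to compound 4 (1.55 log units; beyond the scatter) in this assay. Compound 4 is accordingly estimated at about 150000 ug/mL, with a likely range from 70000 ug/mL to 400000 ug/mL.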

Compound 4, solubility: 20000 ug/mL
Estimate against measurement, compound 4: 7.5-fold (0.88 log units) above; measured number below the stated range.
By their numbers in this assay, from the lowest: compound 2; then compounds 3 and 4 (each within the scatter of the next); then compound 1.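

In this assay, the chain does not give a steady rise in the number as it shortens: a 3.4-fold lower number from compound 1 to compound 4 (0.53 log units; beyond the scatter), so compound 4 goes against the trend set by compounds 1, 2 and 3, and compound 1 holds the highest number of the four. Within the data shown here, changing pentyloxy to ethoxy still gives a 4.8-fold higher number from compound 2 to compound 4 (0.68 log units; beyond the scatter), but that gain is smaller than the one reached with compound 1, and a 1.3-fold higher number from compound 3 to compound 4 (0.12 log units; within the scatter) leaves these two compounds apart by no more than the scatter. Nothing available on these compounds accounts for this turn in the series.

The compounds shown leave open where a methoxy group would fall, and whether a hexyl chain would extend the decline seen towards compound 2. They also leave open how a terminal amine on this chain would read in this assay.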